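Swapping the aryl arm of compound 1 for a short vinyl chain

The source may hold more compounds than are shown below. What is called first, only, known or untested is meant among the compounds shown, and "the series" means these compounds.

Compound 1 `COc1ccc(C(O)(Cc2ccc(F)cc2)c2cccc3ccccc23)c(OC)c1OC`: 7560 nM
Compound 2 `COc1ccc(/C(=N/OC(C)=O)c2cccc3ccccc23)c(OC)c1OC`: > 20000 nM

Among the compounds with values here, in a functional assay on MCF7 cells (Homo sapiens) for inhibition, read by sulforhodamine B assay, with a stated time of 48 h (a lower number here means a stronger inhibitor, a higher number a weaker inhibitor), compound 1 gives 7560 nM, the only actual number in this set. Compound 2 reaches only a limit of the assay, > 20000 nM, so no number is known for it. Compound 1 is therefore the reference point, and compound 3 `C=CCC(O)(c1ccc(OC)c(OC)c1OC)c1cccc2ccccc12` has not yet been tested. Compound 3 differs from compound 1 in one place: vinyl in place of 4-fluorophenyl on a saturated chain carbon, two bonds along the chain from two aromatic carbons and an oxygen on a saturated carbon. Within the data shown here, with no measured pair of this kind to lean on, the size of the step can only be expected. The shorter, non-aromatic group is expected to weaken inhibition somewhat, so compound 3 is estimated at 14000 nM, with a range from 5000 nM to 40000 nM. That means an expected step of a 1.9-fold higher number from compound 1 to compound 3 (0.27 log units; within the scatter), and some chance the assay reports only a limit.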

Compound 3, half-maximal inhibitory concentration: > 20000 nM
Compound 3: a limit, no number; the forecaster's own chance of this, stated with the estimate: 35%; middle value at least 1.4-fold (0.15 log units) away from the limit.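

In this assay, putting vinyl in place of 4-fluorophenyl on this saturated chain carbon gives an at least 2.6-fold higher number from compound 1 to compound 3 (0.42 log units; beyond the scatter). Within the data shown here, this is the first measured change at this position, and the loss of inhibition from compound 1 to compound 3 lies beyond the usual scatter. Compound 3 stands at a limit, > 20000 nM, so the step gives only a minimum, and its full size cannot be read because the values stop there: the limit of > 20000 nM in this assay, at which 2 of the 3 values shown sit.

The compounds shown leave open whether the loss comes from removing the ring, the fluorine or the length of the arm, which a plain phenyl or a longer chain such as butyl could begin to separate. They also do not show how an amine or a carboxylic acid at the end of this arm would fare.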